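Rearranging the Fluoroalkene Side Chain of Compound 1

The source may report more compounds than this note shows. Statements on the series, on what has been measured and on what is new or still open speak of the compounds shown alone.

Compound 1 `C/C(CN(C[C@H]1Cc2ccccc2CN1)[C@H]1CCCc2cccnc21)=C(\F)CN` stands highest of the two compounds measured in an ADME assay for permeability, using PAMPA, with a stated time of 4 h, at pH 5.5; on this read-out lower numbers stand for lower permeability and higher numbers for higher permeability: compound 1 gives 280 nm/s. Its nearest neighbour is compound 2 `N[C@H]1CC[C@H](N(C[C@H]2Cc3ccccc3CN2)[C@H]2CCCc3cccnc32)CC1`, which in this assay gives 6 nm/s; the step of a 47-fold lower number from compound 1 to compound 2 (1.67 log units; beyond the scatter) is large and well beyond the scatter. Compound 3 `C/C(CN)=C(\F)CN(C[C@H]1Cc2ccccc2CN1)[C@H]1CCCc2cccnc21` has not yet been measured. It differs from compound 1 in that (2-(aminomethyl)-1-fluoroprop-1-en-1-yl in place of 3-amino-2-fluoro-1-methylprop-1-en-1-yl on a saturated chain carbon bound to an amine nitrogen); the two have the same atoms, joined differently. Among the compounds with values here, the only measured step, from compound 1 to compound 2, replaces the whole side chain with a ring rather than rearranging the same six heavy atoms within it, so it offers no direct guide to the present change, and nothing among the measured compounds separates the two isomeric arrangements of the chain. The step expected is therefore small, a 1.1-fold lower number from compound 1 to compound 3 (0.05 log units; within the scatter), that is, none beyond the scatter. On that basis compound 3 is estimated to give 250 nm/s in this assay, with a range from 110 nm/s to 550 nm/s.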

Compound 3, apparent permeability: 50 nm/s
The estimate for compound 3 lay 5.0-fold (0.70 log units) above the measured number; measured number below the stated range.
By their numbers in this assay, from the lowest: compound 2; then compound 3; then compound 1.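

In this assay, the place on a saturated chain carbon bound to an amine nitrogen proves sensitive to how the same atoms are joined. Putting 2-(aminomethyl)-1-fluoroprop-1-en-1-yl in place of 3-amino-2-fluoro-1-methylprop-1-en-1-yl gives a 5.6-fold lower number from compound 1 to compound 3 (0.75 log units; beyond the scatter), although the heavy atoms, the double bond, the hydrogen-bond donor and the hydrogen-bond acceptor counted for the two groups stay the same. The earlier compounds showed only the exchange of the whole chain for 4-aminocyclohexyl, whereas the rearranged chain now sits in the middle of the series, with an 8.3-fold higher number from compound 2 to compound 3 (0.92 log units; beyond the scatter), and nothing at hand accounts for the gap between the two arrangements.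

The compounds shown leave open how either chain would read in this assay with a hydrogen or a chlorine atom in place of the fluorine, or with the double bond in the opposite geometry. They also leave open whether a longer chain, with one more carbon before the primary amine, would follow either arrangement.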